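The source may hold more compounds than are shown below. What is called first, only, known or untested is meant among the compounds shown, and "the series" means these compounds.

Three measured compounds stand beside one that is not yet measured. Compound 1, `COc1ncnc2c1ncn2C[C@@H]1C[C@H](O)c2ccccc21`, in an ADME assay on L1210/0 cells (Mus musculus) for cytotoxicity, with a stated time of 48 h (on this read-out lower numbers stand for stronger inhibition and higher numbers for weaker inhibition), gives only a limit, > 200000 nM, not a number. Compound 3, `COC1=C(OCc2ccc([N+](=O)[O-])cc2)/C(=C/CN2CNc3c(Cl)ncnc32)OC1=O`, in this assay gives 13100 nM. Compound 2, `O=c1[nH]c(=O)n([C@H]2C[C@H](O)[C@@H](CO)O2)cc1/C=N/O`, in this assay gives 15500 nM, the highest of the two numbers, though the gap to compound 3 lies within the scatter. Compound 4, `COCC#Cc1cn([C@H]2C[C@H](O)[C@@H](CO)O2)c(=O)[nH]c1=O`, differs from compound 2 in one place: a group of 5 heavy atoms (4 carbon, 1 oxygen; no ring) in place of a group of 3 heavy atoms (1 carbon, 1 nitrogen, 1 oxygen; no ring), on an aromatic carbon. Among the compounds with values here, no step between measured compounds is available, so the size of this change cannot be read from the data. In this assay a step of a 1.9-fold higher number from compound 2 to compound 4 (0.29 log units; within the scatter) is expected, toward weaker inhibition and probably within the scatter. Compound 4 is expected to give 30000 nM, between 5000 nM and 200000 nM.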

Compound 4, half-maximal inhibitory concentration: > 200000 nM
Compound 4 was reported as a limit (the forecaster's own chance of this, stated with the estimate: 20%); middle value at least 6.6-fold (0.82 log units) away from the limit.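

Within the data shown here, with compound 4, the earlier compounds gain their first comparison that differs in one place, and it shows that the aromatic carbon of this ring is sensitive to its substituent in this assay. Placing 3-methoxyprop-1-yn-1-yl there instead of the earlier group gives an at least 12-fold higher number from compound 2 to compound 4 (1.11 log units; beyond the scatter), a large move toward weaker inhibition. This step rests on a limit, not a number: the limit of > 200000 nM in this assay, at which 2 of the 4 values shown sit.

The compounds shown leave open how far the value of compound 4 really lies from that limit. They also leave open whether a plain ethynyl group, a longer chain or an amine at this carbon would stay near compound 2.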